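The source may report more compounds than this note shows. Statements on the series, on what has been measured and on what is new or still open speak of the compounds shown alone.

Working notes on the series, read in an ADME assay on cells (Hepatocyte, Homo sapiens) for metabolic stability, with a stated time of 30 min; on this read-out lower numbers stand for a less stable compound and higher numbers for a more stable compound. Compound 1 `O=c1cc(N2CCN(CC3CCC(NS(=O)(=O)c4ccccc4)CC3)CC2)sc2c([N+](=O)[O-])cc(C(F)(F)F)cc12` gives 90.8% and compound 2 `O=C(NC1CCC(CN2CCN(c3cc(=O)c4cc(C(F)(F)F)cc([N+](=O)[O-])c4s3)CC2)CC1)c1ccccc1` gives 92.9%, a gap of a number 2.1 percentage points higher from compound 1 to compound 2 (within the scatter). Compound 3 `O=C(OC1CCC(CN2CCN(c3cc(=O)c4cc(C(F)(F)F)cc([N+](=O)[O-])c4s3)CC2)CC1)c1ccco1` stands lowest of the three at 1%, with large steps of a number 89.8 percentage points lower from compound 1 to compound 3 (beyond the scatter) and a number 91.9 percentage points lower from compound 2 to compound 3 (beyond the scatter). Compound 4 `O=C(OC1CCC(CN2CCN(c3cc(=O)c4cc(C(F)(F)F)cc([N+](=O)[O-])c4s3)CC2)CC1)c1cccs1` keeps the carbonyl-oxy link of compound 3 and changes only the terminal ring: thiophen-2-yl in place of furan-2-yl on a carbonyl carbon. For the measured compounds named here, no measured step tests this swap, and the large steps concern the link as a whole, so both compounds should stay low. A change of a number 2 percentage points higher from compound 3 to compound 4 (within the scatter) is expected, which is no step beyond the scatter. The estimate for compound 4 is 3%, with an expected range of 0% to 12%.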

Compound 4, percent of the compound remaining: 2.2%
Compound 4: middle estimate off by 0.8 percentage points, on the high side; measured number inside the range.
By their numbers in this assay, from the lowest: compounds 3 and 4 (each within the scatter of the next); then compounds 1 and 2 (each within the scatter of the next).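

In this assay, thiophen-2-yl in place of furan-2-yl on a carbonyl carbon gives a number 1.2 percentage points higher from compound 3 to compound 4 (within the scatter) and so leaves the read-out in place at this position. The low number is therefore not tied to furan-2-yl alone: ((thiophen-2-yl)carbonyl)oxy gives a number 90.7 percentage points lower from compound 2 to compound 4 (beyond the scatter) against benzamido and a number 88.6 percentage points lower from compound 1 to compound 4 (beyond the scatter) against (phenylsulfonyl)amino on the saturated ring carbon. Nothing available explains these steps.

Open, on these data alone, is whether a benzoyloxy group would stay as low as compounds 3 and 4, and whether an ether link carrying thiophen-2-yl would fall with them or stand with compounds 1 and 2.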